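Swapping the aryl group on a sulfonamide core

A few compounds are considered here, and "the series" means these few. Any claim that something is new, unique, unknown or untested is made for them only; others in the source may bear on it.

Compound 1 `CC1CCN(C2CCN(S(=O)(=O)c3ccc(C#N)cc3)CC2)CC1` is the weakest of the three measured compounds in a functional assay on DLD-1 cells (Homo sapiens) for antiproliferative activity, read by CellTiter-Glo, with a stated time of 72 h; on this read-out higher numbers stand for weaker inhibition and lower numbers for stronger inhibition: compound 1 gives 2800 nM, the highest number of the set. Compound 2 `COc1ccccc1-c1ccc(S(=O)(=O)N2CCC(N3CCC(C)CC3)CC2)cc1` gives 26 nM, and compound 3 `CCCOc1ccc(S(=O)(=O)N2CCC(N3CCC(C)CC3)CC2)cc1` gives 452 nM. Both measured steps away from compound 1 point the same way: a 110-fold lower number from compound 1 to compound 2 (2.03 log units; beyond the scatter), and a 6.2-fold lower number from compound 1 to compound 3 (0.79 log units; beyond the scatter). Between those two, a 17-fold higher number from compound 2 to compound 3 (1.24 log units; beyond the scatter).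

Compound 4 `COc1cccc(S(=O)(=O)N2CCC(N3CCC(C)CC3)CC2)c1` has not yet been measured. It differs from compound 1 in one place: 3-methoxyphenyl in place of 4-cyanophenyl on a sulfonyl sulfur. In both measured steps the cyano group of compound 1 was replaced, and the same happens here, but the group that enters, 3-methoxyphenyl, is carried by neither compound 2 nor compound 3, so the size of the effect rests on weaker ground than its direction. Because a 6.2-fold lower number from compound 1 to compound 3 (0.79 log units; beyond the scatter) and a 110-fold lower number from compound 1 to compound 2 (2.03 log units; beyond the scatter), a modest lowering of the number is expected for compound 4 as well, with a wide range around it. For compound 4 the expected value in this assay is 800 nM, within 150 nM to 4000 nM. That amounts to an expected step of a 3.5-fold lower number from compound 1 to compound 4 (0.54 log units; beyond the scatter).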

Compound 4, half-maximal inhibitory concentration: > 5000 nM
Compound 4 gave a limit, no number; the forecaster's own chance of this, stated with the estimate: 3%; middle value at least 6.2-fold (0.79 log units) away from the limit.
By their numbers in this assay, from the lowest: compound 2; then compound 3; then compound 1. At a limit, above all of these: compound 4.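

Compound 4 gives only a limit in this assay, not a number: the limit of > 5000 nM in this assay, at which 1 of the 4 values shown sits. The step reads as an at least 1.7-fold higher number from compound 1 to compound 4 (0.25 log units; that floor lies within the scatter), so this change shows none of the lowering seen when compound 1 was changed into compound 2 or compound 3. Replacing the group on the sulfonyl sulfur therefore does not lower the number as a matter of course, and the counts do not separate these two groups: 3-methoxyphenyl and 4-cyanophenyl match in heavy atoms and in hydrogen-bond acceptors, and both carry no net charge.

On these data alone, how far compound 4 really lies from compound 1 stays open, since its limit sets only a floor and that floor does not clear the usual scatter. Also open, as far as these compounds go, is how the same place on the sulfonyl sulfur would respond to a plain phenyl ring, or to an aryl ring carrying an amine or a carboxylic acid, and so whether the low number of compound 2 depends on its second aromatic ring.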